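Replacing the Whole Aromatic Group on the Ring Amine

The compounds below may be only part of what the source reports. "The series", "measured", "known", "first", "only" and "open" are said of these compounds alone.

Three measured compounds share one core and differ only in the aromatic group attached to the ring amine. In an assay on HEK293 cells for displacement of a labelled ligand from 5-hydroxytryptamine receptor 7 (Rattus norvegicus) (on this read-out lower numbers stand for stronger inhibition and higher numbers for weaker inhibition), compound 1 `CCCc1ccccc1N1CCN(CCCCCC(=O)NC2CCCc3ccccc32)CC1` gives 49.6 nM. Compound 2 `CC(C)(C)c1ccccc1N1CCN(CCCCCC(=O)NC2CCCc3ccccc32)CC1` gives 538 nM in this assay, and compound 3 `CNc1ccccc1N1CCN(CCCCCC(=O)NC2CCCc3ccccc32)CC1` gives 25.4 nM in this assay. Compound 3 holds the lowest of the three numbers; its nearest neighbour is compound 1 (a 2.0-fold lower number from compound 1 to compound 3 (0.29 log units; within the scatter)) and its furthest is compound 2 (a 21-fold lower number from compound 2 to compound 3 (1.33 log units; beyond the scatter)). Compound 4 `O=C(CCCCCN1CCN(c2cccc[n+]2[O-])CC1)NC1CCCc2ccccc21` carries a group of 7 heavy atoms (5 carbon, 1 nitrogen, 1 oxygen; one six-membered aromatic ring with 1 hetero atom) in place of a group of 8 heavy atoms (7 carbon, 1 nitrogen; one six-membered aromatic ring of carbon only), on an amine nitrogen in a ring. Going by the values given here, the steps that bear on this are those altering the same aromatic group: an 11-fold higher number from compound 1 to compound 2 (1.04 log units; beyond the scatter) and a 21-fold lower number from compound 2 to compound 3 (1.33 log units; beyond the scatter) were large, whereas a 2.0-fold lower number from compound 1 to compound 3 (0.29 log units; within the scatter) stayed within the scatter. The change to compound 4 exchanges the whole aromatic group, a wider alteration than any measured step, and a step toward a higher number in this assay, beyond the scatter, is expected. Compound 4 is therefore expected to give 150 nM (range 40 nM to 600 nM). The expected step is a 5.9-fold higher number from compound 3 to compound 4 (0.77 log units; beyond the scatter).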

Compound 4, inhibition constant: 8030 nM
Compound 4: middle estimate off by 54-fold (1.73 log units), on the low side; the whole stated range lies below it.
By their numbers in this assay, from the lowest: compounds 3 and 1 (each within the scatter of the next); then compound 2; then compound 4.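

At this place on the ring amine, the six-membered aromatic ring with 1 hetero atom stands apart from all three groups with a carbon-only ring in this assay (compound 4 lies beyond each: a 320-fold higher number from compound 3 to compound 4 (2.50 log units; beyond the scatter), a 160-fold higher number from compound 1 to compound 4 (2.21 log units; beyond the scatter) and a 15-fold higher number from compound 2 to compound 4 (1.17 log units; beyond the scatter)). Even compound 2, the highest number among the earlier compounds, therefore did not mark the upper end for this position, and exchanging the whole aromatic group moved the number further than changing the group on the carbon-only ring had done. Nothing available on this result explains the size of these steps.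

The compounds shown cannot separate the contribution of the ring nitrogen from that of the oxygen attached to it. A pyridine ring without that oxygen, or a methoxy group on the carbon-only ring, would bear on this question.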